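Working notes: amine headgroup variant in this series

The source may report more compounds than this note shows. Statements on the series, on what has been measured and on what is new or still open speak of the compounds shown alone.

Measured so far:
compound 1 `CCCCCCCCCCc1ccc(-c2noc([C@@H]3CCC[C@@H](N)C3)n2)cc1` — 13%
compound 2 `CCCCCCCCCCc1ccc(-c2noc(CC(O)CN)n2)cc1` — 59%

In an assay on HeLa cells for inhibition of sphingosine-1-phosphate transporter SPNS2 (Mus musculus), read by LC-MS, tested at 2 uM (on this read-out higher numbers stand for more inhibition at the one concentration tested (going by the name of the read-out) and lower numbers for less inhibition), compound 2 gives 59%, the higher of the two numbers; its nearest neighbour is compound 1, which gives 13% in this assay. For the measured compounds named here, the single measured step is a number 46 percentage points higher from compound 1 to compound 2 (beyond the scatter), a change of the whole headgroup on an aromatic carbon.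

Compound 3 `CCCCCCCCCCc1ccc(-c2noc(CC(O)CN3CCCC3)n2)cc1` differs from compound 2 by pyrrolidin-1-yl in place of amino on a saturated chain carbon, two bonds along the chain from an oxygen on a saturated carbon. Going by the values given here, no measured step concerns this position: the step of a number 46 percentage points higher from compound 1 to compound 2 (beyond the scatter) exchanges the headgroup as a whole and says nothing about replacing amino by pyrrolidin-1-yl while the hydroxyl-bearing chain is kept. Among the compounds with values here, with no bearing step, the expectation is a change in this assay of no more than the scatter, in either direction.

Compound 3 is therefore estimated at 55%, with a range of 30% to 80%. The expected step is a number 4 percentage points lower from compound 2 to compound 3 (within the scatter).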

Compound 3, a percentage reported as inhibition, at one concentration (the size of the read-out at that concentration, not a potency): 21%
Compound 3: middle estimate off by 34 percentage points, on the high side; measured number below the stated range.
By their numbers in this assay, from the lowest: compounds 1 and 3 (each within the scatter of the next); then compound 2.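

Working notes, amine end of the chain: in this assay the end of the hydroxyl-bearing chain proves sensitive, since pyrrolidin-1-yl in place of amino alone gives a number 38 percentage points lower from compound 2 to compound 3 (beyond the scatter) while the rest of compound 2 stays unchanged. The hydroxyl-bearing chain therefore does not secure the number of compound 2 on its own, and the comparison with the 3-aminocyclohexyl headgroup reads a number 8 percentage points higher from compound 1 to compound 3 (within the scatter) in this series. Nothing available explains the size of the step between compound 2 and compound 3.

From the compounds shown here alone, it remains open whether methylamino or dimethylamino at this place would track compound 2 or compound 3, and whether piperidin-1-yl or morpholin-4-yl would track pyrrolidin-1-yl. Going by these compounds, the part played by the hydroxyl also remains open, a question that a 3-aminopropyl chain would address.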